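Trading the Naphthyl Arm for a Chlorophenyl Group

The source may hold more compounds than are shown below. What is called first, only, known or untested is meant among the compounds shown, and "the series" means these compounds.

Compound 3 `COc1cc(C2CC(c3cccc4ccccc34)=NN2C(C)=O)ccc1OCc1cn(Cc2ccc([N+](=O)[O-])cc2)nn1` stands highest of the three compounds measured in a functional assay on COLO 205 cells (Homo sapiens) for inhibition, read by sulforhodamine B assay, tested at 10 uM (a lower number here means less inhibition of growth, a higher number more inhibition of growth at the concentration tested), giving 46%. Compound 1 `COc1cc(C2CC(c3ccc(Br)cc3)=NN2C(C)=O)ccc1OCc1cn(Cc2ccc([N+](=O)[O-])cc2)nn1` gives 26% in this assay, and compound 2 `COc1cc(C2CC(c3ccccc3)=NN2C(C)=O)ccc1OCc1cn(Cc2ccc([N+](=O)[O-])cc2)nn1` gives 7%. Compound 4 `COc1cc(C2CC(c3ccc(Cl)cc3)=NN2C(C)=O)ccc1OCc1cn(Cc2ccc([N+](=O)[O-])cc2)nn1` differs from compound 3 by 4-chlorophenyl in place of naphthalen-1-yl on a carbon with a double bond to nitrogen. Going by the values given here, two measured steps bear on this change: a number 20 percentage points higher from compound 1 to compound 3 (beyond the scatter) and a number 39 percentage points higher from compound 2 to compound 3 (beyond the scatter). Running the first of these backwards points to a modest drop, while a number 19 percentage points lower from compound 1 to compound 2 (beyond the scatter) shows that the halogen on the phenyl itself carries weight, and chlorine has not been tested here. Compound 4 is therefore expected to show a step of a number 26 percentage points lower from compound 3 to compound 4 (beyond the scatter). The estimate for compound 4 is 20%, with a range from 5% to 38%.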

Compound 4, percent growth inhibition at one concentration: 0%
For compound 4 the middle estimate is 20 percentage points above the measured one, outside the stated range (below it).
By their numbers in this assay, from the lowest: compounds 4 and 2 (each within the scatter of the next); then compound 1; then compound 3.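

Exchanging naphthalen-1-yl for 4-chlorophenyl gives a number 46 percentage points lower from compound 3 to compound 4 (beyond the scatter) in this assay, a larger loss than the bromo and phenyl compounds had shown. The halogen's identity also matters: chloro in place of bromo gives a number 26 percentage points lower from compound 1 to compound 4 (beyond the scatter), whereas chloro in place of hydrogen gives a number 7 percentage points lower from compound 2 to compound 4 (within the scatter), so a halogen on the phenyl does not by itself confer the inhibition seen with bromo. Going by these compounds, whether a methoxy group or an amine on the phenyl, or naphthalen-2-yl at this carbon, would retain inhibition remains open. Nothing available here explains these differences.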